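Moving the ring nitrogen: compound 2 to compound 3

The compounds below may be only part of what the source reports. "The series", "measured", "known", "first", "only" and "open" are said of these compounds alone.

Among the compounds with values here, compound 2 `Cc1cc(Oc2ccc(Cn3nc4ccc(Cl)cc4c3C(=O)NS(=O)(=O)c3ccc(NCc4cccnc4)c([N+](=O)[O-])c3)cc2)cc(C)c1Cl` gives 1180 nM in an assay on isolated protein for inhibition of Apoptosis regulator Bcl-2 (Homo sapiens), read by fluorescence polarization (a lower number here means a stronger inhibitor, a higher number a weaker inhibitor), the higher of the two numbers measured so far; compound 1 `Cc1cc(Oc2ccc(Cn3nc4ccc(Cl)cc4c3C(=O)NS(=O)(=O)c3ccc(NCc4ccco4)c([N+](=O)[O-])c3)cc2)cc(C)c1Cl` gives 570 nM. Within the data shown here, the only measured step is a 2.1-fold higher number from compound 1 to compound 2 (0.32 log units; beyond the scatter), which concerns a different exchange. Compound 3 `Cc1cc(Oc2ccc(Cn3nc4ccc(Cl)cc4c3C(=O)NS(=O)(=O)c3ccc(NCc4ccncc4)c([N+](=O)[O-])c3)cc2)cc(C)c1Cl` differs from compound 2 by pyridin-4-yl in place of pyridin-3-yl on a saturated chain carbon bound to a nitrogen on an aromatic ring. Among the measured compounds shown here, no measured step bears directly on this change, so for compound 3 an estimate of a 1.1-fold higher number from compound 2 to compound 3 (0.04 log units; within the scatter) is expected, a shift within the scatter. The estimate for compound 3 is 1300 nM, with a range from 600 nM to 2800 nM.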

Compound 3, inhibition constant: 1520 nM
The estimate for compound 3 lay 1.2-fold (0.07 log units) below the measured number; low and high end bracket the measured number.
By their numbers in this assay, from the lowest: compound 1; then compounds 2 and 3 (each within the scatter of the next).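

In this assay, moving the ring nitrogen from pyridin-3-yl to pyridin-4-yl gives a 1.3-fold higher number from compound 2 to compound 3 (0.11 log units; within the scatter) and so does not separate the two pyridines at this place on the saturated chain carbon. Exchanging furan-2-yl for pyridin-4-yl gives a 2.7-fold higher number from compound 1 to compound 3 (0.43 log units; beyond the scatter) and so leaves compound 3, like compound 2, on the weaker side of compound 1. No supporting evidence explains these differences. The compounds shown leave open whether phenyl or thiophen-2-yl here would read with compound 1 or with the pyridines, and how a saturated amine such as piperidin-4-yl would read.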